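Bromo for (methylsulfanyl)methyl on the fused core

The source may report more compounds than this note shows. Statements on the series, on what has been measured and on what is new or still open speak of the compounds shown alone.

Measured compounds:
compound 1, `CCOCc1c(C)nc2c(OCc3ccccc3)cccn12`: 84%
compound 2, `CSCc1c(C)nc2c(OCc3ccccc3)cccn12`: 29%

In a functional assay on the whole organism with Rattus norvegicus as the target, with a stated time of 4 h, at a dose of 40 mg/kg by the intraperitoneal route (on this read-out lower numbers stand for less inhibition and higher numbers for more inhibition at the one dose given (going by the name of the read-out)), compound 2 gives 29%, the lowest of the two numbers; its nearest neighbour is compound 1 at 84%, and that gap is beyond the scatter. Among the compounds with values here, the one measured step is a number 55 percentage points lower from compound 1 to compound 2 (beyond the scatter), a large drop.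

Compound 3, `Cc1nc2c(OCc3ccccc3)cccn2c1Br`, is not yet measured. It differs from compound 2 by bromo in place of (methylsulfanyl)methyl on an aromatic carbon. Within the data shown here, no measured step makes this same exchange; the step from compound 1 to compound 2 touches the same saturated chain carbon bound to an aromatic carbon, but it swaps one chain for another, whereas here the whole (methylsulfanyl)methyl leaves and a single bromine enters on the aromatic carbon. The shown data therefore give no direction for this change, only that substituents at this place have moved this assay by as much as a number 55 percentage points lower from compound 1 to compound 2 (beyond the scatter). Compound 3 is estimated at 55%, with a range of 20% to 85%, which means an expected step of a number 26 percentage points higher from compound 2 to compound 3 (beyond the scatter) from compound 2 to compound 3, upward but with wide uncertainty.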

Compound 3, a percentage reported as inhibition, in the whole organism at one dose (the size of the read-out at that dose, not a potency): 26%
Beside the measured number, compound 3's estimate is 29 percentage points above it; the measured number falls inside the stated range.
By their numbers in this assay, from the lowest: compounds 3 and 2 (each within the scatter of the next); then compound 1.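

In this assay, bromo in place of (methylsulfanyl)methyl on this aromatic carbon gives a number 3 percentage points lower from compound 2 to compound 3 (within the scatter), so a single bromine and the sulfur-bearing chain cannot be told apart at this place. Bromo in place of ethoxymethyl gives a number 58 percentage points lower from compound 1 to compound 3 (beyond the scatter), so compound 1 now stands apart from two different replacements rather than from only one. Among these three compounds, having a chain at this place is therefore not enough for the large read-out: compound 1 carries one and reads high, whereas compound 2 also carries one and still sits within the scatter of the chainless compound 3. The data shown offer no measured property or other finding that would explain this pattern.

The compounds shown leave open whether the large read-out belongs to the ether oxygen of ethoxymethyl or to that particular chain, which a methoxymethyl or a longer propoxymethyl group at the same aromatic carbon could help separate. They also leave open whether an aminomethyl group or a carboxylic acid there would read with compound 1 or with compound 2 and compound 3.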